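Working notes: a smaller polyol ether on compound 2

The compounds below may be only part of what the source reports. "The series", "measured", "known", "first", "only" and "open" are said of these compounds alone.

Among the measured compounds shown here, compound 2 `CCCCCCCCCCCCCCCCO[C@H]1O[C@H](COCC(CO)(CO)CO)[C@@H](O)[C@H](O)[C@H]1NC(=O)CCCC` gives 17 uM in a functional assay on A-375 cells (Homo sapiens), read by thymidine incorporation (on this read-out lower numbers stand for stronger inhibition and higher numbers for weaker inhibition), the only true number so far. Compound 1 `CC(=O)N[C@H]1[C@@H](OCCCCc2ccccc2)O[C@H](CO)[C@@H](O)[C@@H]1O` gives > 50 uM in this assay, which is a limit and not a number. Compound 3 `CCCCC(=O)N[C@H]1[C@@H](OCCc2ccccc2)O[C@H](COCC(O)CO)[C@@H](O)[C@@H]1O` gives > 50 uM in this assay, again a limit and not a number.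

Compound 4 `CCCCCCCCCCCCCCCCO[C@H]1O[C@H](COC[C@@H](O)CO)[C@@H](O)[C@H](O)[C@H]1NC(=O)CCCC` keeps the rest of compound 2 and carries 1,2-dihydroxyethyl in place of 2-hydroxy-1,1-bis(hydroxymethyl)ethyl on a saturated chain carbon bound to an oxygen on a saturated carbon. For the measured compounds named here, no measured pair isolates this change, so the only anchor is compound 2 at 17 uM. Going by the values given here, compounds 1 and 3 differ from compound 2 in more than this one place and give no size for the step.

The expected change is a 1.2-fold higher number from compound 2 to compound 4 (0.07 log units; within the scatter), with no direction expected beyond the scatter. For compound 4 the estimated value is 20 uM, with an expected range of 9 uM to 45 uM.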

Compound 4, concentration for 50% inhibition: 3.4 uM
For compound 4 the middle estimate is 5.9-fold (0.77 log units) above the measured one, and the stated range ends above it.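

Among the compounds shown here, this is the first step that can be sized, and it falls at the ether arm of the shared core. In this assay the step is a 5.0-fold lower number from compound 2 to compound 4 (0.70 log units; beyond the scatter), so on a saturated chain carbon bound to an oxygen on a saturated carbon, the full 2-hydroxy-1,1-bis(hydroxymethyl)ethyl group is not needed for inhibition, and 1,2-dihydroxyethyl, with 4 heavy atoms in place of 7, gives the lower number. No second step at this place can be read, because the other compounds in the series stay at a limit and not a number: the limit of > 50 uM in this assay, at which 2 of the 4 values shown sit.

Still open is whether the defined stereocentre of 1,2-dihydroxyethyl contributes to the step, as its mirror-image arm is not among the compounds shown. Also open, going by these compounds, is how an amine or a carboxylic acid at this same place would read.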